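The source may hold more compounds than are shown below. What is called first, only, known or untested is meant among the compounds shown, and "the series" means these compounds.

For the measured compounds named here, in a functional assay on A2780 cells (Homo sapiens) for inhibition (a higher number here means a weaker inhibitor, a lower number a stronger inhibitor), compound 1 `CCNC(=O)c1noc(-c2cc(C(C)C)c(O)cc2O)c1-c1cc(CN)no1` has "not determined" (no result reported) as its entry, so compound 2 `CCNC(=O)c1noc(-c2cc(C(C)C)c(O)cc2O)c1-c1cc(C(N)=O)no1` at 15 nM carries the only number available and cannot be ranked against any other. Compound 3 `CCNC(=O)c1noc(-c2cc(C(C)C)c(O)cc2O)c1-c1cc(C(=O)NC)no1` differs from compound 2 in one place, with methyl in place of hydrogen on an amide-type nitrogen as the change: methyl in place of hydrogen on an amide-type nitrogen. Going by the values given here, no measured step guides the expectation, so only a small move toward a higher number in this assay is expected, perhaps none beyond the scatter. The estimated change is a 1.3-fold higher number from compound 2 to compound 3 (0.12 log units; within the scatter) for this pair. Compound 3 is expected at 20 nM within a range of 8 nM to 55 nM by this estimate.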

Compound 3, half-maximal inhibitory concentration: 100 nM
Compound 3: the middle estimate sits 5.0-fold (0.70 log units) below what was measured, and the stated range ends below it.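

In this assay the amide hydrogen of the 3-carbamoyl-1,2-oxazol-5-yl group proves sensitive to change: replacing it with methyl gives a 6.7-fold higher number from compound 2 to compound 3 (0.82 log units; beyond the scatter) and lies beyond the scatter. For the compounds shown here, this is the first measured step at this position, and it shows that one added carbon on the amide-type nitrogen is enough to weaken inhibition. No evidence on the cause of this step is available. Going by these compounds, whether a longer chain such as ethyl on that nitrogen would weaken inhibition further remains open. So does how a carboxylic acid in place of the carbamoyl group would compare.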